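The source may report more compounds than this note shows. Statements on the series, on what has been measured and on what is new or still open speak of the compounds shown alone.

Measured compounds:
- compound 1, `Cn1nc(-c2nnc(SCCOc3ccccc3F)o2)cc1-c1ccc(C(F)(F)F)cc1`: 48100 nM
- compound 2, `Cn1nc(-c2nnc(SCc3cccc(Cl)c3Cl)o2)cc1-c1ccc(C(F)(F)F)cc1`: 54300 nM
- compound 3, `Cn1nc(-c2ccc(C(F)(F)F)cc2)cc1-c1nnc(SCCOc2ccccc2F)o1`: 68100 nM

In a functional assay on A549 cells (Homo sapiens) for cytotoxicity, read by MTT assay, with a stated time of 24 h (on this read-out lower numbers stand for stronger inhibition and higher numbers for weaker inhibition), the three measured compounds sit close together. Compound 3 gives the highest of the three numbers, but its distance to compound 2 and to compound 1 stays within the scatter, so no order among them is claimed.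

Compound 1 and compound 2 share a core and differ in one place: 2,3-dichlorophenyl in place of (2-fluorophenoxy)methyl on a saturated chain carbon bound to a sulfur. In this assay this gave a 1.1-fold higher number from compound 1 to compound 2 (0.05 log units; within the scatter), a step that cannot be told apart from repeat measurement.

Compound 3 is built on a different core; the difference between the two cores is not broken down here. Compound 4, `Cn1nc(-c2ccc(C(F)(F)F)cc2)cc1-c1nnc(SCc2cccc(Cl)c2Cl)o1`, has not yet been measured in this assay. It stands to compound 3 as compound 2 stands to compound 1, and the change is the same: 2,3-dichlorophenyl in place of (2-fluorophenoxy)methyl on a saturated chain carbon bound to a sulfur.

Among the measured compounds shown here, since the one measured instance of this change, a 1.1-fold higher number from compound 1 to compound 2 (0.05 log units; within the scatter), lay within the scatter, the step expected for compound 4 is also small, a 1.1-fold higher number from compound 3 to compound 4 (0.04 log units; within the scatter). For compound 4 in this assay the estimate is 75000 nM, with a range from 37000 nM to 150000 nM. This rests on a single pair, so the expectation carries the uncertainty of one observation.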

Compound 4, half-maximal inhibitory concentration: 84200 nM
The estimate for compound 4 lay 1.1-fold (0.05 log units) below the measured number; the range from low to high includes it.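

In this assay the same replacement, 2,3-dichlorophenyl in place of (2-fluorophenoxy)methyl on a saturated chain carbon bound to a sulfur, was now read on a second core, and it gave a 1.2-fold higher number from compound 3 to compound 4 (0.09 log units; within the scatter). Set beside the earlier instance, the two steps cannot be told apart: the same change on two cores in this assay, a 1.1-fold higher number (0.05 log units; within the scatter) from compound 1 to compound 2 and a 1.2-fold higher number (0.09 log units; within the scatter) from compound 3 to compound 4, 1.1-fold (0.04 log units) apart, within the scatter of two such steps. This shows that the change behaved alike on these two cores, leaving the number within the scatter on both, but it does not show a real effect that carries from one core to another, since neither step can be distinguished from repeat measurement and two cores are too few to support a rule for the series.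

The compounds shown leave open whether a quite different group on that sulfur, such as a plain longer alkyl chain, an amine or a carboxylic acid, would give a step beyond the scatter on either core. They also leave open what would follow if the trifluoromethyl group, present in all four compounds, gave way to another group, such as a methoxy group or a nitrile.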